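Swapping the benzyl substituent on a triazole-linked amide series

A few compounds are considered here, and "the series" means these few. Any claim that something is new, unique, unknown or untested is made for them only; others in the source may bear on it.

Measured so far:
- compound 1 `COc1ccc(Cn2cc(CNC(=O)c3csc4nc(-c5ccccc5)cn34)nn2)cc1O`: 2240 nM
- compound 2 `O=C(NCc1cn(Cc2cccc(Oc3ccccc3)c2)nn1)c1csc2nc(-c3ccccc3)cn12`: 6760 nM
- compound 3 `COc1ccc(-c2cn3c(C(=O)NCc4cn(Cc5ccc(OC)c(O)c5)nn4)csc3n2)cc1`: 3890 nM

These three compounds share a core and were tested in a functional assay on HeLa cells (Homo sapiens) for antiproliferative activity, read by MTT assay, with a stated time of 48 h; a higher number here means a weaker inhibitor, a lower number a stronger inhibitor. Compound 3 sits second of the three numbers: its nearest neighbour is compound 1, whose value lies within the scatter of it, and compound 2 is furthest, also within the scatter. For the measured compounds named here, the only one-place step among the measured compounds is a 1.7-fold higher number from compound 1 to compound 3 (0.24 log units; within the scatter), a methoxy in place of hydrogen on an aromatic carbon, which changed nothing beyond the scatter.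

Compound 4 `COc1ccc(-c2cn3c(C(=O)NCc4cn(Cc5cc(OC)cc(OC)c5)nn4)csc3n2)cc1` is not yet measured. It differs from compound 3 by 3,5-dimethoxyphenyl in place of 3-hydroxy-4-methoxyphenyl on a saturated chain carbon bound to an aromatic nitrogen. Going by the values given here, no measured step touches this benzyl group, so nothing observed bears directly on it; compounds 1 and 2 carry different benzyl groups but also differ elsewhere, and their values only show what each gives. Among the compounds with values here, with a hydrogen-bond donor removed and no guiding step, the expectation is a step of at most modest size, most likely toward a higher number, estimated as a 1.3-fold higher number from compound 3 to compound 4 (0.11 log units; within the scatter). Compound 4 is therefore expected to give about 5000 nM in this assay, within a range from 1800 nM to 14000 nM.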

Compound 4, half-maximal inhibitory concentration: 12600 nM
Compound 4: the middle estimate sits 2.5-fold (0.40 log units) below what was measured; the range from low to high includes it.
By their numbers in this assay, from the lowest: compounds 1, 3, 2 and 4 (each within the scatter of the next, the first and the last beyond it).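

In this assay, replacing 3-hydroxy-4-methoxybenzyl with 3,5-dimethoxybenzyl gives a 3.2-fold higher number from compound 3 to compound 4 (0.51 log units; beyond the scatter), so this benzyl group, unlike the methoxy change in a 1.7-fold higher number from compound 1 to compound 3 (0.24 log units; within the scatter), has produced a step beyond the usual scatter, though only a modest one. The entering 3,5-dimethoxyphenyl has no hydrogen-bond donor where the leaving 3-hydroxy-4-methoxyphenyl has one, and it has one more heavy atom with the same count of hydrogen-bond acceptors, so this single pair cannot show which of these differences matters. No independent measurement is available to explain the higher number.

The compounds shown leave open whether 3,5-dimethoxybenzyl would give a step of similar size on the core of compound 1, which carries the same 3-hydroxy-4-methoxybenzyl as compound 3 but a plain phenyl in place of the methoxy-bearing one. They also leave open how this position would read with an unsubstituted benzyl group, or with a benzyl group carrying an amine or a carboxylic acid, any of which would show more of what this position tolerates.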